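A few compounds are considered here, and "the series" means these few. Any claim that something is new, unique, unknown or untested is made for them only; others in the source may bear on it.

Compound 2, with the structure `O=C(c1ccccc1)c1cccc(NS(=O)(=O)c2ccc(Cl)cc2Cl)c1`, is a sulfonamide that was tested in an assay on CHO cells for binding affinity to integrin alpha-1 (Homo sapiens), read by WST assay, with a stated time of 2 h (a higher number here means that more compound is needed for the effect, a lower number that less compound is needed), where compound 2 gives 17000 nM. Its companion compound 1, with the structure `O=C(c1ccccc1)c1ccc(NS(=O)(=O)c2ccc(Cl)cc2Cl)cc1`, differs from compound 2 only in where the benzoyl group is attached to the aniline ring; in this assay compound 1 gives 20000 nM. The two numbers lie within the scatter of each other, so neither compound can be set apart from the other on this evidence.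

Compound 3, with the structure `CC(=O)c1cccc(NS(=O)(=O)c2ccc(Cl)cc2Cl)c1`, is a shortened relative of compound 2. The change between them is methyl in place of phenyl on a carbonyl carbon. Going by the values given here, nothing among the measured pairs speaks to a change of this kind, so the expectation rests on the weak numbers of both measured compounds. For compound 3 the step from a 1.5-fold higher number from compound 2 to compound 3 (0.17 log units; within the scatter) is expected to stay close to, or a little beyond, the scatter, toward a higher number. Compound 3 is therefore estimated at 25000 nM, with a range from 8000 nM to 80000 nM, in this assay.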

Compound 3, half-maximal effective concentration: "not active" (no number reported)
No number was reported for compound 3, so the estimate cannot be set against anything.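

Going by these compounds alone, compound 3 is reported as not active in this assay, without a number, and no step from compound 2 to compound 3 can be read. The compounds shown leave open how far benzoyl to acetyl shifts the number. No other evidence shown bears on this result.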